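The compounds below may be only part of what the source reports. "The series", "measured", "known", "first", "only" and "open" are said of these compounds alone.

Of the compounds shown here, two have so far been measured in a functional assay on RAW264.7 cells (Mus musculus) for inhibition, read by Griess assay, with stated times of 2 h and 18 h; on this read-out lower numbers stand for stronger inhibition and higher numbers for weaker inhibition. Compound 1 `C=C1[C@@H]([C@@]2(C)C=CC(=O)C(C)(C)[C@@H]2CC(=O)OC)[C@@H](OC(C)=O)[C@H](OC(C)=O)[C@@]2(C)[C@H](C3=CC(O)OC3=O)C[C@H]3O[C@]132` gives 41400 nM there, and compound 2 `C=C1[C@@H]([C@@]2(C)C=CC(=O)C(C)(C)[C@@H]2CC(=O)OC)[C@H](OC(C)=O)[C@H](C(C)=O)[C@@]2(C)[C@H](C3=CCOC3=O)C[C@H]3O[C@]132` gives 20900 nM. Compound 1 carries the larger of these two numbers, but the gap to compound 2 lies within the usual scatter, so the two cannot be told apart. Compound 3 `C=C1[C@@H]([C@@]2(C)C=CC(=O)C(C)(C)[C@@H]2CC(=O)OC)[C@@H](OC(C)=O)[C@H](OC(C)=O)[C@@]2(C)[C@H](C3=CC(=O)OC3O)C[C@H]3O[C@]132` differs from compound 1 in a single place: a group of 7 heavy atoms (4 carbon, 3 oxygen; one five-membered non-aromatic ring with 1 hetero atom) in place of a group of 7 heavy atoms (4 carbon, 3 oxygen; one five-membered non-aromatic ring with 1 hetero atom), on a saturated ring carbon. For the measured compounds named here, no measured pair shows such a change, so the step from compound 1 to compound 3 is expected to stay within the scatter, a 1.0-fold lower number from compound 1 to compound 3 (0.01 log units; within the scatter) either way. Compound 3 is therefore estimated at 40000 nM, between 15000 nM and 100000 nM.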

Compound 3, half-maximal inhibitory concentration: 38900 nM
Compound 3: middle estimate off by 1.0-fold (0.01 log units), on the high side; measured number inside the range.
By their numbers in this assay, from the lowest: compounds 2, 3 and 1 (each within the scatter of the next).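

In this assay joining the same atoms differently in the group on this saturated ring carbon gives a 1.1-fold lower number from compound 1 to compound 3 (0.03 log units; within the scatter) and so leaves the two groups indistinguishable on this read-out. For the compounds shown here, this is the first measured pair that differs at this place, and it shows that this rearrangement within the five-membered ring keeps the number inside the scatter. No measurement shown here offers an explanation for this result. Still open, on these data alone, is whether a different group at this place, such as a carboxylic acid or an amine in place of the ring, would give a step beyond the scatter.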